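Adding a hydroxy group to the anilino ring

This account rests on a few compounds, and the source may have more. Where it says the series, first, only, none or still open, it means among the compounds named here.

Values in a functional assay on HCC827 cells (Homo sapiens) for inhibition, read by fluorescence, with a stated time of 72 h; a higher number here means a weaker inhibitor of growth, a lower number a stronger inhibitor of growth:
- compound 1 `CCCCCCn1cnc2c(Nc3ccc(O)cc3)nc(N[C@H]3CC[C@H](N)CC3)nc21` gives 24700 nM
- compound 2 `CC(C)CCn1cnc2c(Nc3cccc(Cl)c3)nc(N[C@H]3CC[C@H](N)CC3)nc21` gives 10300 nM
- compound 3 `CC(C)CCn1cnc2c(Nc3ccccc3)nc(N[C@H]3CC[C@H](N)CC3)nc21` gives 21700 nM

Compound 3 at 21700 nM lies within the scatter of compound 1 and on the weaker side of compound 2. The next compound, compound 4 `CC(C)CCn1cnc2c(Nc3ccc(O)cc3)nc(N[C@H]3CC[C@H](N)CC3)nc21`, has yet to be measured. It differs from compound 3 by hydroxy in place of hydrogen on an aromatic carbon and this turns phenyl to 4-hydroxyphenyl.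

Going by the values given here, only one measured step concerns a change on this ring. It runs a 2.1-fold higher number from compound 2 to compound 3 (0.32 log units; beyond the scatter) and is modest, but it involves chloro rather than hydroxy, so it gives no direct guide to this change. Compound 1 already carries the 4-hydroxyphenyl group on a different chain, and compound 1 gives 24700 nM in this assay which is within the scatter of compound 3. A shift beyond the scatter is therefore not expected, and the expected step is a 1.0-fold lower number from compound 3 to compound 4 (0.01 log units; within the scatter) in this assay overall.

Compound 4 is estimated at 21000 nM with an expected range from 10000 nM to 45000 nM in this assay for now.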

Compound 4, concentration for 50% growth inhibition: 14400 nM
Compound 4: the middle estimate sits 1.5-fold (0.16 log units) above what was measured; the range from low to high includes it.
By their numbers in this assay, from the lowest: compounds 2, 4, 3 and 1 (each within the scatter of the next, the first and the last beyond it).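

In this assay, hydroxy on this ring, para to a large group, can now be read directly against hydrogen with the chain held constant, and the step is a 1.5-fold lower number from compound 3 to compound 4 (0.18 log units; within the scatter), so this change cannot be told apart from no effect. The 4-hydroxyphenyl group also cannot be separated from 3-chlorophenyl, with a 1.4-fold higher number from compound 2 to compound 4 (0.15 log units; within the scatter), even though the step from 3-chlorophenyl to phenyl lies beyond the scatter. The chain difference also stays within the scatter, at a 1.7-fold lower number from compound 1 to compound 4 (0.23 log units; within the scatter).

No measurement shown here bears on the reason for these numbers. From the compounds shown here alone, it remains open whether a methoxy group or an amine in the same place on the ring would part from phenyl, and whether hydroxy elsewhere on that ring would behave as it does here.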